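The source may hold more compounds than are shown below. What is called first, only, known or untested is meant among the compounds shown, and "the series" means these compounds.

Measured compounds and their values:
Compound 1 `COc1nc(-c2ccsc2)ccc1[C@@H](c1ccccc1)[C@@](O)(CCN(C)C)c1cccc2ccccc12`: a limit of > 64 ug/mL in a toxicity assay on HeLa cells (Homo sapiens) for cytotoxicity; on this read-out lower numbers stand for higher toxicity in this test and higher numbers for lower toxicity in this test
Compound 2 `COc1ccc(-c2ccc([C@@H](c3ccccc3)[C@@](O)(CCN(C)C)c3cccc4ccccc34)c(OC)n2)cc1`: a limit of > 64 ug/mL in this assay
Compound 3 `COc1nc(-c2ccc(C(F)(F)F)cc2)ccc1[C@@H](c1ccccc1)[C@@](O)(CCN(C)C)c1cccc2ccccc12`: a limit of > 64 ug/mL in this assay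

Among the measured compounds shown here, compound 3 stands at the limit of > 64 ug/mL in this assay, at which 3 of the 3 values shown sit, so none of the measured steps can be sized: a step that the two limits leave unreadable from compound 1 to compound 2, a step that the two limits leave unreadable from compound 1 to compound 3 and a step that the two limits leave unreadable from compound 2 to compound 3. Compound 4 `COc1nc(-c2cccc(F)c2)ccc1[C@@H](c1ccccc1)[C@@](O)(CCN(C)C)c1cccc2ccccc12` differs from compound 3 in one place: 3-fluorophenyl in place of 4-(trifluoromethyl)phenyl on an aromatic carbon. For the measured compounds named here, no measured step bears readably on this change, and nothing seen so far reaches a number in this assay. Compound 4 is therefore expected to give about 80 ug/mL, between 40 ug/mL and 200 ug/mL, most likely again only as a limit. The expected step is thus a step that the limit leaves unreadable from compound 3 to compound 4, none beyond the scatter.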

Compound 4, half-maximal cytotoxic concentration: 62.8 ug/mL
Estimate against measurement, compound 4: 1.3-fold (0.11 log units) above, within the range that was stated.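

In this assay compound 4 is the only compound shown that gives a number, 62.8 ug/mL, so 3-fluorophenyl at this position, next to the ring nitrogen, is the one group here that reaches a readable value. The steps are an at least 1.0-fold lower number from compound 3 to compound 4 (0.00 log units; that floor lies within the scatter), an at least 1.0-fold lower number from compound 2 to compound 4 (0.00 log units; that floor lies within the scatter) and an at least 1.0-fold lower number from compound 1 to compound 4 (0.00 log units; that floor lies within the scatter), so no change is shown beyond the scatter. Compound 1, compound 2 and compound 3 remain limits of the assay: the limit of > 64 ug/mL in this assay, at which 3 of the 4 values shown sit.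

From the compounds shown here alone, their true distance from compound 4 stays open. So does whether an unsubstituted phenyl, 4-fluorophenyl, or a phenyl carrying an amine or a carboxylic acid would give a number here.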